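A few compounds are considered here, and "the series" means these few. Any claim that something is new, unique, unknown or untested is made for them only; others in the source may bear on it.

Among the compounds with values here, compound 2 `CCCCCCCCN1C(=O)[C@@H](Cc2ccc(-c3cc(OC)c(OC)c(OC)c3)cc2)N(C)C(=O)[C@@H]1C` gives 68 nM in a functional assay for agonist activity at follicle-stimulating hormone receptor (Homo sapiens), read by a luciferase reporter (a higher number here means that more compound is needed for the effect, a lower number that less compound is needed), the lower of the two numbers so far, though the step of a 1.8-fold lower number from compound 1 to compound 2 (0.25 log units; within the scatter) is within the scatter, so compound 2 and compound 1 `CCCCCCCCN1C(=O)[C@H](Cc2ccc(-c3cc(OC)c(OC)c(OC)c3)cc2)N(C)C(=O)[C@H]1C`, which gives 120 nM, are not told apart. Compound 3 `CCCCCCCCN1C(=O)[C@@H](Cc2ccc(-c3cc(OC)c(OC)c(OC)c3)cc2)N(C)C(=O)[C@H]1C` differs from compound 2 in that (the two compounds have the same atoms and bonds and differ only in configuration as drawn: 1 of 2 stereo elements differ; a stereocentre at a saturated ring carbon is drawn S in compound 2 and R in compound 3); nothing leaves and nothing enters. Within the data shown here, only one measured step exists, and it inverts both stereocentres together, because of the fact that compounds 1 and 2 differ only in the configuration as drawn; that step, a 1.8-fold lower number from compound 1 to compound 2 (0.25 log units; within the scatter), stayed within the scatter. Among the measured compounds shown here, no measured pair inverts a single stereocentre, so the step to compound 3 has no direct precedent. Compound 3 is expected to sit near compound 2, with an estimated step of a 1.6-fold higher number from compound 2 to compound 3 (0.21 log units; within the scatter) but a wide range. In this assay compound 3 is estimated to give about 110 nM, between 30 nM and 450 nM.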

Compound 3, half-maximal effective concentration: 1600 nM
Compound 3: middle estimate off by 15-fold (1.16 log units), on the low side, outside the stated range (above it).
By their numbers in this assay, from the lowest: compounds 2 and 1 (each within the scatter of the next); then compound 3.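

In this assay, changing a single stereocentre matters a great deal: one inversion gives a 24-fold higher number from compound 2 to compound 3 (1.37 log units; beyond the scatter), and inverting the other stereocentre instead gives a 13-fold higher number from compound 1 to compound 3 (1.12 log units; beyond the scatter). The earlier step inverted both stereocentres together and stayed within the scatter, so across these three compounds the number follows how the two centres are set relative to each other, not either centre alone. With atoms and bonds unchanged, the large gap can be put down to configuration alone: the fact that compounds 2 and 3 differ only in the configuration as drawn.

Still open, from the compounds shown here alone, is whether the mirror image of compound 3 would give a number close to that of compound 3, which would show whether this relative setting is what counts. Also open, going by these compounds, is whether the same gap between stereoisomers would appear with a carboxylic acid or an amine carried on the shared core.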